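Chain variation on a trimethoxybenzyl purine-like scaffold

The source may report more compounds than this note shows. Statements on the series, on what has been measured and on what is new or still open speak of the compounds shown alone.

Of the compounds shown here, three sharing one core have been tested in a functional assay on MCF7 cells (Homo sapiens) for antiproliferative activity; a higher number here means a weaker inhibitor, a lower number a stronger inhibitor. Compound 1 `C#CCCCn1c(Cc2cc(OC)c(OC)c(OC)c2)nc2c(N)nc(F)nc21` gives 11000 nM. Compound 2 `CCCCCn1c(Cc2cc(OC)c(OC)c(OC)c2)nc2c(N)ncnc21` gives 61700 nM, and compound 3 `COc1cc(Cc2nc3c(N)ncnc3n2CC(C)C)cc(OC)c1OC` gives 97700 nM. Among the compounds with values here, compound 3 and compound 2 cannot be told apart, since the step of a 1.6-fold higher number from compound 2 to compound 3 (0.20 log units; within the scatter) stays inside the scatter; compound 1, however, gives a clearly lower number than compound 3, though compound 1 also carries a fluorine on the core that compound 3 lacks, so no single-change step exists between them.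

Compound 4 `C#CCCCn1c(Cc2cc(OC)c(OC)c(OC)c2)nc2c(N)ncnc21` has not yet been measured. It differs from compound 3 in one place: but-3-yn-1-yl in place of isopropyl on a saturated chain carbon bound to an aromatic nitrogen. Within the data shown here, the only measured step on this chain carbon, from compound 2 to compound 3, was within the scatter, so a chain change alone has so far moved nothing. Compound 4 carries the same chain as compound 1 but lacks its fluorine, so its value in this assay is expected to fall between compound 1 and compound 3, closer to compound 1, an expected step of a 3.9-fold lower number from compound 3 to compound 4 (0.59 log units; beyond the scatter). Compound 4 is therefore estimated at 25000 nM, with a range from 8000 nM to 80000 nM.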

Compound 4, half-maximal inhibitory concentration: 24000 nM
The estimate for compound 4 lay 1.0-fold (0.02 log units) above the measured number; the measured number falls inside the stated range.
By their numbers in this assay, from the lowest: compound 1; then compound 4; then compounds 2 and 3 (each within the scatter of the next).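

In this assay, this position on the chain can matter after all: the earlier chain step stayed within the scatter, but but-3-yn-1-yl in place of isopropyl gives a 4.1-fold lower number from compound 3 to compound 4 (0.61 log units; beyond the scatter). The comparison with the saturated chain is tighter. Only the chain end differs: ethynyl in place of ethyl, three bonds along the chain from an aromatic nitrogen, gives a 2.6-fold lower number from compound 2 to compound 4 (0.41 log units; beyond the scatter), so in this pair the triple-bonded end goes with the lower number, even though the step is modest. The result also separates the two differences carried by compound 1, since hydrogen in place of fluoro on an aromatic carbon gives a 2.2-fold higher number from compound 1 to compound 4 (0.34 log units; beyond the scatter), which shows that the chain alone does not account for the low number of compound 1.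

No measurement shown here explains why either change shifts the number. On these data alone, it remains open whether a nitrile at the chain end or a longer alkyne chain would match the triple-bonded end, and whether fluoro would give a similar step on a core carrying the saturated pentyl chain.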